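The source may hold more compounds than are shown below. What is called first, only, known or untested is meant among the compounds shown, and "the series" means these compounds.

Measured compounds:
- compound 1, `Oc1ccc(-c2cc(-c3ccc(F)cc3)cc(-c3ccc(O)cc3)n2)cc1`, 4970 nM
- compound 2, `Oc1ccc(-c2cc(-c3ccccc3C(F)(F)F)cc(-c3ccccc3O)n2)cc1`, 8990 nM

Both compounds were tested in a functional assay on HCT-15 cells (Homo sapiens) for inhibition; a higher number here means a weaker inhibitor, a lower number a stronger inhibitor. Compound 1 gives 4970 nM and compound 2 gives 8990 nM. Compound 2 thus sits at one end of the two numbers, but its gap to compound 1 lies within the usual scatter of this assay, so the two cannot be told apart on these data.

Compound 3 is `Oc1ccc(-c2cc(-c3ccccc3C(F)(F)F)cc(-c3ccc(O)cc3)n2)cc1`. It differs from compound 2 in one place: 4-hydroxyphenyl in place of 2-hydroxyphenyl on an aromatic carbon. After this change compound 3 carries the same 4-hydroxyphenyl group at both positions flanking the ring nitrogen, as compound 1 does, while keeping the 2-(trifluoromethyl)phenyl group of compound 2.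

For the measured compounds named here, no measured pair shows this exact change, so its size is unknown. Since compound 1 gives 4970 nM and compound 2 gives 8990 nM, and the two lie within the scatter, the step is expected to be small, with no clear direction beyond the scatter, estimated as a 1.5-fold lower number from compound 2 to compound 3 (0.18 log units; within the scatter). Compound 3 is therefore expected to give about 6000 nM in this assay, with a likely range from 2000 nM to 18000 nM.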

Compound 3, half-maximal inhibitory concentration: > 50000 nM
Compound 3 gave a limit, no number; the forecaster's own chance of this, stated with the estimate: 5%; at least 8.3-fold (0.92 log units) between middle value and limit.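

In this assay, for the compounds shown here, placing 4-hydroxyphenyl instead of 2-hydroxyphenyl on the aromatic carbon next to the ring nitrogen gives an at least 5.5-fold higher number from compound 2 to compound 3 (0.74 log units; beyond the scatter), so with the same atoms joined differently, this position distinguishes between the two hydroxyphenyl groups in a way the earlier compounds could not show. Keeping the 4-hydroxyphenyl groups and placing 2-(trifluoromethyl)phenyl instead of 4-fluorophenyl on an aromatic carbon gives an at least 10-fold higher number from compound 1 to compound 3 (1.00 log units; beyond the scatter), so that substituent also matters when 4-hydroxyphenyl occupies both positions next to the ring nitrogen. The value for compound 3 is a limit of the assay and not a number, so neither step has a known full size: the limit of > 50000 nM in this assay, at which 1 of the 3 values shown sits.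

The compounds shown leave open whether the step from 2-hydroxyphenyl to 4-hydroxyphenyl would be as large with 4-fluorophenyl in place of 2-(trifluoromethyl)phenyl on the shared core. They also leave open how this position would respond to a phenyl group bearing an amine or a carboxylic acid in place of the hydroxyl.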